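The source may hold more compounds than are shown below. What is called first, only, known or untested is meant among the compounds shown, and "the series" means these compounds.

Measured so far:
compound 1 `COc1cc(C=C(C(=O)/C=C/c2cccc(OC)c2OC)C(=O)/C=C/c2cccc(OC)c2OC)ccc1O`, 480 nM
compound 2 `COc1ccc(C=C(C(=O)/C=C/c2cccc(OC)c2OC)C(=O)/C=C/c2cccc(OC)c2OC)cc1OC`, 560 nM
compound 3 `COc1ccc(OC)c(/C=C/C(=O)C(=Cc2ccc(O)c(OC)c2)C(=O)/C=C/c2cc(OC)ccc2OC)c1`, 400 nM

All three were run in a functional assay on MCF7 cells (Homo sapiens) for antiproliferative activity, read by sulforhodamine B assay, with a stated time of 48 h; on this read-out higher numbers stand for weaker inhibition and lower numbers for stronger inhibition. Compound 1 and compound 2 differ in one place: methyl in place of hydrogen on an oxygen on an aromatic ring. That step reads a 1.2-fold higher number from compound 1 to compound 2 (0.07 log units; within the scatter), so the two values are not told apart. Compound 3 has the same atoms as compound 1, joined differently; the difference between the two cores is not broken down here. Compound 4 `COc1ccc(OC)c(/C=C/C(=O)C(=Cc2ccc(OC)c(OC)c2)C(=O)/C=C/c2cc(OC)ccc2OC)c1` is not yet measured. It stands to compound 3 as compound 2 stands to compound 1: methyl in place of hydrogen on an oxygen on an aromatic ring, the same change at the same place. The expected step is a 1.2-fold higher number from compound 3 to compound 4 (0.08 log units; within the scatter) because a 1.2-fold higher number from compound 1 to compound 2 (0.07 log units; within the scatter) lay within the scatter, and a single prior instance gives no ground for a larger move. Compound 4 is therefore expected at 480 nM, with a range from 280 nM to 850 nM.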

Compound 4, half-maximal inhibitory concentration: 850 nM
Beside the measured number, compound 4's estimate is 1.8-fold (0.25 log units) below it, within the range that was stated.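

On the core of compound 3, hydroxy to methoxy in this assay gives a 2.1-fold higher number from compound 3 to compound 4 (0.33 log units; beyond the scatter) while on the core of compound 1 the same change gives a 1.2-fold higher number from compound 1 to compound 2 (0.07 log units; within the scatter) and so the two cores seem to part at first sight. Set side by side, the two steps are not told apart: the same change on two cores in this assay, a 1.2-fold higher number (0.07 log units; within the scatter) from compound 1 to compound 2 and a 2.1-fold higher number (0.33 log units; beyond the scatter) from compound 3 to compound 4, 1.8-fold (0.26 log units) apart, within the scatter of two such steps. The change therefore carries between these two cores without a measurable difference, but two pairs do not show that the cores respond alike or fix the size of the step on either core.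

Only hydroxy and methoxy appear at this place on the aromatic ring. On these data alone, what an ethoxy group, a longer chain or an amine there would give stays open.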